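This account rests on a few compounds, and the source may have more. Where it says the series, first, only, none or still open, it means among the compounds named here.

Compound 1 `COc1cccc(OC)c1OCCNCCOc1ccccc1OCc1ccccc1` gives 8.39
Compound 2 `COc1cccc(OC)c1OCCNCCOc1ccccc1OCc1cccc(Cl)c1` gives 8.12
Compound 3 `COc1cccc(OC)c1OCCNCCOc1ccccc1OCc1cccc([N+](=O)[O-])c1` gives 8.85

All three were measured in a functional assay on Vas deferens for antagonist activity at Alpha-1A adrenergic receptor (Rattus norvegicus); on this read-out higher numbers stand for higher potency (the scale is a negative logarithm) and lower numbers for lower potency. Compound 1 stands second highest of the three numbers: its nearest neighbour is compound 2, with a number 0.27 log units lower from compound 1 to compound 2 (within the scatter), and the furthest is compound 3, with a number 0.46 log units higher from compound 1 to compound 3 (beyond the scatter). The remaining measured step is a number 0.73 log units higher from compound 2 to compound 3 (beyond the scatter).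

Compound 4 `COc1ccc(COc2ccccc2OCCNCCOc2c(OC)cccc2OC)cc1` is not yet measured. It differs from compound 1 in one place: methoxy in place of hydrogen on an aromatic carbon. Within the data shown here, the steps that bear on it are the two substitutions on the same ring, one within the scatter and one modest; neither places a methoxy there, and no step involves a methoxy at all. In this assay the expected step is therefore small, a number 0.09 log units lower from compound 1 to compound 4 (within the scatter), with no clear direction. Compound 4 is estimated at 8.3, in the range 7.8 to 8.8.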

Compound 4, negative logarithm of the antagonist equilibrium constant: 8.54
The estimate for compound 4 lay 0.24 log units below the measured number; measured number inside the range.
By their numbers in this assay, from the lowest: compounds 2, 1 and 4 (each within the scatter of the next, the first and the last beyond it); then compound 3.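

In this assay, the 4-methoxybenzyl group takes the place of benzyl without a step beyond the scatter (a number 0.15 log units higher from compound 1 to compound 4 (within the scatter)). Against the other substituted benzyl compounds, the 4-methoxyphenyl compound sits apart on both sides, with one modest step down (a number 0.31 log units lower from compound 3 to compound 4 (beyond the scatter)) and one modest step up (a number 0.42 log units higher from compound 2 to compound 4 (beyond the scatter)), each changing both the group and its place on the ring. No evidence is available to account for these steps.

Open, going by these compounds, is whether an amine or a carboxylic acid on this ring would keep the number. Also open, on these data alone, is how methoxy behaves at another carbon of the ring, and how nitro or chloro behaves para to the large group.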